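Ether side-chain swap on two related saturated amine cores

This account rests on a few compounds, and the source may have more. Where it says the series, first, only, none or still open, it means among the compounds named here.

Compound 1 `CN1CC[C@@H]2CC[C@H](OCc3ccccc3)C[C@@H]21` and compound 2 `COCCO[C@H]1CC[C@H]2CCN(C)[C@H]2C1` share one core and differ only in the group attached through the ether oxygen. In an assay on HEK293 cells for displacement of a labelled ligand from Neuronal acetylcholine receptor; alpha3/beta4 (Rattus norvegicus), with a stated time of 4 h (a lower number here means a stronger inhibitor, a higher number a weaker inhibitor), compound 1 gives 100000 nM, and compound 2 gives 300000 nM. The change between them, (methoxymethyl in place of phenyl on a saturated chain carbon bound to an oxygen on a saturated carbon), produced a 3.0-fold higher number from compound 1 to compound 2 (0.48 log units; beyond the scatter).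

Compound 3 `CN1CCC2=CC[C@H](OCc3ccccc3)C[C@@H]21` carries the same phenyl-bearing ether as compound 1 but sits on a different core; the difference between the two cores is not broken down here. In this assay compound 3 gives 300000 nM, a number level with that of compound 2 at the digits shown and the joint highest of the three measured values.

Compound 4 `COCCO[C@H]1CC=C2CCN(C)[C@H]2C1` is the unmeasured partner of compound 3. The difference between compound 3 and compound 4 is methoxymethyl in place of phenyl on a saturated chain carbon bound to an oxygen on a saturated carbon, the same change that turned compound 1 into compound 2. Since both place descriptions read alike, the change is the same one, now applied on the core of compound 3 rather than that of compound 1.

Because a 3.0-fold higher number from compound 1 to compound 2 (0.48 log units; beyond the scatter) was seen for this change on the other core, a step of similar size is expected here. Compound 4 is expected to give 900000 nM. For compound 4 this corresponds to an expected step of a 3.0-fold higher number from compound 3 to compound 4 (0.48 log units; beyond the scatter). The expected range for compound 4 runs from 300000 nM to 3000000 nM, and with compound 3 already so weak there is a real chance that the measurement for compound 4 is reported only as a limit.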

Compound 4, inhibition constant: > 300000 nM
Compound 4: no number, only a limit; the forecaster's own chance of this, stated with the estimate: 40%; the middle value is on the limit's open side.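

In this assay compound 4 gives > 300000 nM as a limit of the assay and not a number. With methoxymethyl in place of phenyl on the core of compound 3, the result is a number no lower from compound 3 to compound 4 (the limit leaves the size open) and the size of this step cannot be read, so the comparison with the step on the core of compound 1 stands as follows: the same change on two cores in this assay, a 3.0-fold higher number (0.48 log units; beyond the scatter) from compound 1 to compound 2 and a number no lower (the limit leaves the size open) from compound 3 to compound 4; the limit leaves it open whether they differ. The result therefore gives no sign against the change carrying over from one core to the other, but it does not show that the step has the same size on both cores, and with only two cores shown it supports no wider rule for the series.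

The compounds shown leave open how far the number for compound 4 lies from that of compound 3, and so whether methoxymethyl costs the same on each core. They also leave open how a longer chain, an amine or a carboxylic acid in place of phenyl on a saturated chain carbon bound to an oxygen on a saturated carbon would read in this assay on either core.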